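The source may report more compounds than this note shows. Statements on the series, on what has been measured and on what is new or still open speak of the compounds shown alone.

Measured compounds:
Compound 1, `C[C@H](NC(=O)CN(c1nc(Cl)nc2[nH]cnc12)C1CC1)C(=O)O` – 43.5%
Compound 2, `CC(C)[C@H](NC(=O)CN(c1ncnc2c1ncn2C1CCCCO1)C1CC1)C(=O)OCc1ccccc1` – 30.1%

Of the compounds shown here, two have been measured in a functional assay on the whole organism (Tail, strain ICR) with Mus musculus as the target, in the tail flick test, with a stated time of 90 min, at a dose of 25 umol/kg by the oral route (on this read-out higher numbers stand for a stronger effect at the one dose given and lower numbers for a weaker effect), where compound 1 gives 43.5%. In this assay compound 2 gives 30.1%, the lower of the two numbers; the number for compound 1 lies higher by a margin beyond the usual scatter. These two compounds differ in several places at once, so their gap cannot be pinned to any single change.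

Compound 3, `O=C(CN(c1ncnc2c1ncn2C1CCCCO1)C1CC1)NCC(=O)OCc1ccccc1`, has not been measured. It is reached from compound 2 by one change: hydrogen in place of isopropyl on a saturated chain carbon bound to an amide-type nitrogen and a carbonyl carbon. Within the data shown here, no measured pair shows this change alone, so its effect has to be judged from the structural change itself. Because compound 2 gives 30.1%, compound 3 is expected to land somewhat lower, with the step of a number 5.1 percentage points lower from compound 2 to compound 3 (within the scatter) estimated to be small, most likely within or just beyond the scatter. Compound 3 is therefore estimated to give 25% in this assay, within a range from 8% to 42%.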

Compound 3, a percentage reported as activity, at one dose (the size of the read-out at that dose, not a potency): 25.9%
Estimate against measurement, compound 3: 0.9 percentage points below, within the range that was stated.
By their numbers in this assay, from the lowest: compounds 3 and 2 (each within the scatter of the next); then compound 1.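

In this assay, among these compounds, hydrogen in place of isopropyl on a saturated chain carbon bound to an amide-type nitrogen and a carbonyl carbon gives a number 4.2 percentage points lower from compound 2 to compound 3 (within the scatter) and this is the first change that can be read on its own. At the one dose given, the read-out does not separate the compound carrying isopropyl at this place from the one carrying hydrogen, so on this pair the isopropyl group is not needed to hold the effect within the scatter. This holds only for the structure that compound 2 and compound 3 share, at one dose and one time, and it says nothing about potency. Nothing at hand gives a reason for this outcome.

The compounds shown leave open whether a longer chain, a benzyl group or an amine on this chain carbon would move the number beyond the scatter, which the swap of isopropyl for hydrogen alone cannot tell. Compound 1 differs from both compound 2 and compound 3 in several places, and its gap to them cannot be read as the effect of any one change.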